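The compounds below may be only part of what the source reports. "The series", "measured", "known", "first", "only" and "open" are said of these compounds alone.

compound 1 `O=C(NCCCCc1ccccc1)n1c2c(oc1=O)CNCC2`: > 2 h
compound 2 `CN1CCN(c2ccc3c(c2)oc(=O)n3C(=O)NCCCCc2ccccc2)C(=O)C1`: 0.333 h

In an ADME assay on a cell-free system (plasma, Mus musculus) for metabolic stability, read by LC-MS, tested at 2 uM (a lower number here means that the compound disappears faster, a higher number that the compound lasts longer), compound 1 is recorded as > 2 h, which is a limit of the assay and not a number. Going by the values given here, compound 2, at 0.333 h, therefore holds the only actual number, and it is the one compound of the two with a half-life measured inside the range of the assay.

The next compound is compound 3 `CCN1CCN(c2ccc3c(c2)oc(=O)n3C(=O)NCCCCc2ccccc2)CC1`. It carries 4-ethylpiperazin-1-yl in place of 4-methyl-2-oxopiperazin-1-yl on an aromatic carbon, and the rest of the structure of compound 2 stays unchanged (4-ethylpiperazin-1-yl in place of 4-methyl-2-oxopiperazin-1-yl on an aromatic carbon). Among the compounds with values here, no measured step between two compounds is available to show how much such a swap moves this assay. The starting point for the expectation is therefore compound 2 at 0.333 h, and no change beyond the scatter is expected, in either direction. The expected result is a 1.2-fold higher number from compound 2 to compound 3 (0.08 log units; within the scatter). For compound 3 the estimated half-life is 0.4 h, with an expected range from 0.15 h to 1.1 h.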

Compound 3, half-life: < 0.0834 h
Compound 3: a limit, no number; the forecaster's own chance of this, stated with the estimate: 5%; middle value at least 4.7-fold (0.68 log units) from the limit.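

In this assay, the group on this aromatic carbon, para to a fused ring and meta to a fused ring, proves decisive: placing 4-ethylpiperazin-1-yl there in place of 4-methyl-2-oxopiperazin-1-yl gives an at least 3.9-fold lower number from compound 2 to compound 3 (0.60 log units; beyond the scatter), the first step the series offers, and it shows that two six-membered rings of equal heavy-atom count can part clearly at this place. Compound 3 gives < 0.0834 h, which is a limit of the assay and not a number. The step therefore has a known minimum but no known full size, because compound 3 sits at the lower end of what is reported: the limit of < 0.0834 h in this assay, at which 1 of the 3 values shown sits.

As far as these compounds go, the swap removes the ring carbonyl and replaces methyl with ethyl at once, so it remains open which of the two changes carries the step, and 4-methylpiperazin-1-yl at the same place would separate them. Compound 1 gives > 2 h, a limit of the assay and not a number, and it differs from the other compounds in more than one place, so it offers no comparison for this position.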